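The compounds below may be only part of what the source reports. "The series", "measured", "known", "first", "only" and "open" are said of these compounds alone.

In a functional assay for inhibition, with Rattus norvegicus as the target (on this read-out higher numbers stand for weaker inhibition and lower numbers for stronger inhibition), compound 1 `CC(/N=c1\c(O)c(O)\c1=N/c1cccnc1)C(C)(C)C` gives 1950 nM, and compound 2 `CC(C)(C)/N=c1\c(O)c(O)\c1=N/c1cccnc1` gives 2800 nM. Going by the values given here, these two numbers lie within the scatter of each other, so compound 1 sits level with the only other measured compound. Compound 3 `CC(/N=c1\c(O)c(O)\c1=N/c1cccnc1O)C(C)(C)C` keeps the core of compound 1 and turns pyridin-3-yl into 2-hydroxypyridin-3-yl: hydroxy in place of hydrogen on an aromatic carbon. This puts hydroxy in place of hydrogen on an aromatic carbon, next to the ring nitrogen. Among the compounds with values here, the one measured step, a 1.4-fold higher number from compound 1 to compound 2 (0.16 log units; within the scatter), exchanges 1,2,2-trimethylpropyl for tert-butyl on a double-bonded nitrogen and leaves the aromatic ring untouched. Within the data shown here, it therefore says little about this change, and no measured step points in a direction, so no step beyond the scatter can be expected with confidence. The expected step is a 1.3-fold higher number from compound 1 to compound 3 (0.11 log units; within the scatter). For compound 3 the estimated value is 2500 nM, with an expected range from 500 nM to 12000 nM.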

Compound 3, half-maximal inhibitory concentration: > 30000 nM
Compound 3: a limit, no number; the forecaster's own chance of this, stated with the estimate: 15%; at least 12-fold (1.07 log units) between middle value and limit.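

The earlier compounds shown here differ only in the group on the double-bonded nitrogen, whereas this change falls on the aromatic ring and gives an at least 15-fold higher number from compound 1 to compound 3 (1.18 log units; beyond the scatter) in this assay, so adding a single hydroxy at this place, next to the ring nitrogen, is enough to cost a large part of the inhibition. Compound 3 gives > 30000 nM, which is a limit of the assay and not a number. How much inhibition compound 3 still has therefore stays unknown, and the step marks only the smallest size the loss can have: the limit of > 30000 nM in this assay, at which 1 of the 3 values shown sits.

Whether the loss belongs to hydroxy itself or would follow any group on this carbon stays open, as the compounds shown carry only hydrogen or hydroxy here. An amine, a methoxy group or a methyl group at this place would help to separate those two readings.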